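Replacing Methyl with Trifluoromethyl in Compound 1

The source may report more compounds than this note shows. Statements on the series, on what has been measured and on what is new or still open speak of the compounds shown alone.

In an ADME assay on Vero cells (Chlorocebus sabaeus) for cytotoxicity, read by resazurin assay, with a stated time of 72 h (a higher number here means a weaker inhibitor, a lower number a stronger inhibitor), three compounds sharing one core have been measured. Compound 1 (`Cc1ccc(C(=O)CCN2CCN(c3ccc(F)cc3)CC2)cc1`) gives 55400 nM, the lowest number of the three. Compound 2 (`O=C(CCN1CCN(c2ccc(F)cc2)CC1)c1ccc(F)c(Br)c1`) gives 352000 nM, and compound 3 (`O=C(CCN1CCN(c2ccc(F)cc2)CC1)c1ccc(F)c(F)c1`) gives 385000 nM.

Compound 4 (`O=C(CCN1CCN(c2ccc(F)cc2)CC1)c1ccc(C(F)(F)F)cc1`) has trifluoromethyl in place of methyl on an aromatic carbon. Within the data shown here, no measured step makes this exact change. The closest ones also remove the 4-methylphenyl of compound 1. Putting 3-bromo-4-fluorophenyl there gave a 6.4-fold higher number from compound 1 to compound 2 (0.80 log units; beyond the scatter), and 3,4-difluorophenyl gave a 6.9-fold higher number from compound 1 to compound 3 (0.84 log units; beyond the scatter). Those two replacements hardly differ, with a 1.1-fold higher number from compound 2 to compound 3 (0.04 log units; within the scatter), which lies within the scatter. Both new groups carry fluorine, as trifluoromethyl does, but neither is the same group, so the guide is loose. A rise in the number is expected, probably smaller than those two steps. The expected size is a 3.6-fold higher number from compound 1 to compound 4 (0.56 log units; beyond the scatter). For compound 4 the estimated value is 200000 nM, with an expected range from 80000 nM to 450000 nM.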

Compound 4, half-maximal inhibitory concentration: 28500 nM
Compound 4: middle estimate off by 7.0-fold (0.85 log units), on the high side; measured number below the stated range.
By their numbers in this assay, from the lowest: compounds 4 and 1 (each within the scatter of the next); then compounds 2 and 3 (each within the scatter of the next).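

In this assay, the change from methyl to trifluoromethyl on this aromatic carbon, para to a large group, gives a 1.9-fold lower number from compound 1 to compound 4 (0.29 log units; within the scatter), so compound 1 and compound 4 cannot be told apart here. Fluorine in the group at this position therefore does not by itself bring the rise seen in a 6.4-fold higher number from compound 1 to compound 2 (0.80 log units; beyond the scatter) or in a 6.9-fold higher number from compound 1 to compound 3 (0.84 log units; beyond the scatter), and the position accepts 4 heavy atoms in place of 1 without a change beyond the scatter. Nothing available here explains why this step stays so small.

Still open, on these data alone, is whether a single fluoro, a chloro, a methoxy or a nitrile on this same carbon would also leave the number in place. Also open, as far as these compounds go, is whether an amine or a carboxylic acid there would shift it.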